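Methyl on the piperidine ring: from compound 3 to compound 4

The source may hold more compounds than are shown below. What is called first, only, known or untested is meant among the compounds shown, and "the series" means these compounds.

Measured compounds:
Compound 1, `CC1CCN(c2ccc(Nc3ncc4c(n3)N(C3CCCC3)CC(=O)N4)nc2)CC1`, > 30000 nM (a limit of the assay)
Compound 2, `CN1CCN(c2ccc(Nc3ncc4c(n3)N(C3CCCC3)CC(=O)N4C)nc2)CC1`, 9730 nM
Compound 3, `CN1C(=O)CN(C2CCCC2)c2nc(Nc3ccc(N4CCCCC4)cn3)ncc21`, 3890 nM

In a functional assay on HCT-116 cells (Homo sapiens) for inhibition, read by MTT assay, with a stated time of 48 h (a lower number here means a stronger inhibitor, a higher number a weaker inhibitor), compound 3 gives 3890 nM, the lowest of the two numbers shown. Compound 2 sits a 2.5-fold lower number from compound 2 to compound 3 (0.40 log units; beyond the scatter) above it. Compound 1 gives only a limit, > 30000 nM, at the limit of > 30000 nM in this assay, at which 1 of the 3 values shown sits.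

Compound 4, `CC1CCN(c2ccc(Nc3ncc4c(n3)N(C3CCCC3)CC(=O)N4C)nc2)CC1`, carries methyl in place of hydrogen on a saturated ring carbon. For the measured compounds named here, no measured step covers this change: the one measured step concerns the ring itself, and compound 1 differs from compound 4 in two places, so it bears only loosely. Compound 4 is therefore expected at 5000 nM, between 1500 nM and 20000 nM, a step of a 1.3-fold higher number from compound 3 to compound 4 (0.11 log units; within the scatter), within the scatter.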

Compound 4, half-maximal inhibitory concentration: > 30000 nM
Compound 4 gave a limit, no number; the forecaster's own chance of this, stated with the estimate: 15%; middle value at least 6.0-fold (0.77 log units) from the limit.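

In this assay, methyl on a saturated ring carbon, three ring bonds from the ring nitrogen, gives an at least 7.7-fold higher number from compound 3 to compound 4 (0.88 log units; beyond the scatter). Replacing 4-methylpiperazin-1-yl with 4-methylpiperidin-1-yl gives an at least 3.0-fold higher number from compound 2 to compound 4 (0.48 log units; beyond the scatter), so the piperidine ring does not keep its edge over the piperazine ring once it carries this methyl. The value of compound 4, > 30000 nM, is a limit, and its step to compound 1 cannot be read: the limit of > 30000 nM in this assay, at which 2 of the 4 values shown sit.

On these data alone, it remains open whether a hydroxyl, an amine or an ethyl on this ring carbon would give a lower number than methyl does.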